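The source may hold more compounds than are shown below. What is called first, only, known or untested is meant among the compounds shown, and "the series" means these compounds.

Series of three measured compounds in an ADME assay on a cell-free system (plasma, Homo sapiens) for metabolic stability, read by LC-MS, with a stated time of 60 min, at 37 degrees C, tested at 50 uM; on this read-out higher numbers stand for a more stable compound and lower numbers for a less stable compound. Compound 1 `C[C@@H](O)[C@H]1C(=O)N2C3=C(S[C@@H]4CN[C@@H](C4)C(=O)Nc4cccc(c4)C(=O)OCOCOC3=O)[C@H](C)[C@H]12` gives 60% in this assay. Compound 2 `C[C@@H](O)[C@H]1C(=O)N2C(C(=O)OCc3oc(=O)oc3C(C)(C)C)=C(S[C@@H]3CN[C@H](C(=O)Nc4cccc(C(=O)OCc5oc(=O)oc5C(C)(C)C)c4)C3)[C@H](C)[C@H]12` gives 10% in this assay. Compound 3 `CC(C)C(=O)OCOC(=O)C1=C(S[C@@H]2CN[C@H](C(=O)Nc3cccc(C(=O)O)c3)C2)[C@H](C)[C@@H]2[C@@H]([C@@H](C)O)C(=O)N12` gives 15% in this assay, the second highest of the three numbers; against compound 2 the gap lies within the scatter, so the two cannot be ordered, while against compound 1 the gap lies beyond the scatter and compound 1 stands clearly higher. For the measured compounds named here, no pair of measured compounds differs in one place, so no measured step is available.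

Compound 4 `CCC(CC)C(=O)OCOC(=O)C1=C(S[C@@H]2CN[C@H](C(=O)Nc3cccc(C(=O)O)c3)C2)[C@H](C)[C@@H]2[C@@H]([C@@H](C)O)C(=O)N12` is not yet measured. It differs from compound 3 as follows: pentan-3-yl in place of isopropyl on a carbonyl carbon. The change is confined to the group on the carbonyl carbon, with the same donor and acceptor count before and after. Going by the values given here, with no comparable step measured, the expectation for compound 4 is a step from compound 3 of a number 5 percentage points higher from compound 3 to compound 4 (within the scatter), upward if anything, but not clearly beyond the scatter. Compound 4 is estimated at 20%, within 8% to 40%.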

Compound 4, percent of the compound remaining: 82%
Compound 4: middle estimate off by 62 percentage points, on the low side; measured number above the stated range.
By their numbers in this assay, from the lowest: compounds 2 and 3 (each within the scatter of the next); then compound 1; then compound 4.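

In this assay the group on the carbonyl carbon turns out to be a sensitive place: pentan-3-yl in place of isopropyl brings a number 67 percentage points higher from compound 3 to compound 4 (beyond the scatter) in the percent of compound remaining. The entering group has 5 heavy atoms against 3, all carbon, with no ring, no hydrogen-bond donors or acceptors and no net charge on either side, and the rest of the structure stays the same, so a purely carbon change at this one place is enough for a large step. Nothing at hand bears on what lies behind this step.

A single step leaves open whether the number follows chain size or the branched shape of the group; a tert-butyl group, a straight pentyl chain or a cyclohexyl ring on the same carbonyl carbon would separate these. Going by these compounds, whether the same change gives a comparable step on another part of the series also stays open.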